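A few compounds are considered here, and "the series" means these few. Any claim that something is new, unique, unknown or untested is made for them only; others in the source may bear on it.

Working notes on the thromboxane synthase series, step from compound 1 to compound 4.

Compound 1 `O=C(O)CCCC/C=C(/c1ccc(Br)cc1)c1cccnc1` is the reference point. In an assay (Equus caballus) for inhibition of Thromboxane-A synthase (Homo sapiens), using microsomes (on this read-out lower numbers stand for stronger inhibition and higher numbers for weaker inhibition), compound 1 gives 82 nM, the highest of the three numbers in hand. Compound 2 `COc1ccc(/C(=C/CCCCC(=O)O)c2cccnc2)cc1` gives 80 nM in this assay, and compound 3 `CSC(CCC/C=C(\c1ccccc1)c1cccnc1)C(=O)O` gives 30 nM in this assay; the gap from compound 1 to compound 2 is within the scatter, the gap from compound 1 to compound 3 lies beyond it.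

Compound 4 `O=C(O)CCCC/C=C(\c1cccnc1)c1cccc(Br)c1` is not yet measured. It differs from compound 1 in one place: 3-bromophenyl in place of 4-bromophenyl on a double-bonded chain carbon bound to an aromatic carbon and a double-bonded chain carbon

Among the measured compounds shown here, only one measured step is in hand, a 1.0-fold lower number from compound 1 to compound 2 (0.01 log units; within the scatter), which concerns the same position on the same ring but swaps the group rather than moving it. For the measured compounds named here, no step in hand moves a substituent on the aromatic ring, so the relevance of that step to compound 4 is indirect; it indicates only that this ring tolerates a change at that position without a measurable shift. On that basis no step beyond the scatter is expected from compound 1 to compound 4, a 1.0-fold lower number from compound 1 to compound 4 (0.01 log units; within the scatter), with the range kept wide for want of a direct precedent. Compound 4 is estimated at 80 nM in this assay, with a plausible range from 35 nM to 190 nM.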

Compound 4, half-maximal inhibitory concentration: 180 nM
Compound 4: the middle estimate sits 2.3-fold (0.35 log units) below what was measured; measured number inside the range.
By their numbers in this assay, from the lowest: compound 3; then compounds 2 and 1 (each within the scatter of the next); then compound 4.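

Moving the bromine from 4-bromophenyl to 3-bromophenyl, with the same atoms and the same counts on both sides, gives a 2.2-fold higher number from compound 1 to compound 4 (0.34 log units; beyond the scatter) in this assay, a modest step. The earlier step, a 1.0-fold lower number from compound 1 to compound 2 (0.01 log units; within the scatter), changed the group while keeping its place on the ring and showed no separation, whereas this one shows that on the double-bonded chain carbon the read-out can respond to where the bromine stands on the ring. No measurement on hand offers an explanation for this step.

Among the compounds shown here, whether the same move gives a step of similar size with other groups on this ring, such as methoxy, a chlorine or a nitrile, remains open, since the bromine is the only group seen in both arrangements. On these data alone, compound 3 differs from compound 1 in more than one place, so it also remains open whether the step would carry over to a chain bearing a carboxylic acid with a methylthio group on the carbon beside it.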